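Switching the amide partner of compound 3 to a thiazole

This account rests on a few compounds, and the source may have more. Where it says the series, first, only, none or still open, it means among the compounds named here.

Compounds measured so far:
compound 1, `NCc1csc(NC(=O)c2ccccn2)n1`, 0.7
compound 2, `NCc1csc(NC(=O)c2ncccn2)n1`, -0.1
compound 3, `CC(C)(C)c1cc(C(=O)Nc2cccc(CN)c2)n(Cc2ccccc2)n1`, 2.9

In a physicochemical assay for lipophilicity, read by HPLC, at pH 7.4 (a higher number here means a more lipophilic compound, a lower number a more polar compound), compound 3 stands highest of the three numbers, well beyond the scatter above compound 1 and further still above compound 2. Compound 4, `CNCc1csc(NC(=O)c2cc(C(C)(C)C)nn2Cc2ccccc2)n1`, keeps the shared core of compound 3 and differs from it in one place: 4-((methylamino)methyl)-1,3-thiazol-2-yl in place of 3-(aminomethyl)phenyl on an amide-type nitrogen. For the measured compounds named here, no measured pair shows this exact change, so its size is uncertain. Compound 4 is expected to fall below compound 3 in this assay by a moderate step, a number 0.70 log units lower from compound 3 to compound 4 (beyond the scatter), clearly beyond the scatter. Starting from the value of compound 3, 2.9, compound 4 is estimated at 2.2, within a range from 1.4 to 3.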

Compound 4, distribution coefficient: 3.8
Estimate against measurement, compound 4: 1.60 log units below, outside the stated range (above it).
By their numbers in this assay, from the lowest: compound 2; then compound 1; then compound 3; then compound 4.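

In this assay, for the compounds shown here, the exchange on an amide-type nitrogen gives a number 0.90 log units higher from compound 3 to compound 4 (beyond the scatter) as the only one-place step, showing that this position can move the read-out upward. The entering 4-((methylamino)methyl)-1,3-thiazol-2-yl matches 3-(aminomethyl)phenyl in heavy atoms and carries more hydrogen-bond acceptors, yet the number still rose. Nothing available accounts for this rise.

The step joins a ring exchange with a methyl on the amine, and the compounds shown do not separate the two. From the compounds shown here alone, how a dimethylamino group or a carboxylic acid on that side chain would read remains open.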